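Phosphorus epimer of a cyclic phosphate prodrug: half-life outlook

A few compounds are considered here, and "the series" means these few. Any claim that something is new, unique, unknown or untested is made for them only; others in the source may bear on it.

Measured so far:
compound 1 `CCc1cc(C(=O)OCO[P@@]2(=O)OCC(C)(C)[C@H](C(=O)NCCC(=O)OC)O2)n(C)n1` — >= 0.97 h
compound 2 `COC(=O)CCNC(=O)[C@@H]1O[P@](=O)(OCOC(=O)c2cc(C)nn2C)OCC1(C)C` — < 0.16 h

In an ADME assay on blood (Homo sapiens) for pharmacokinetics (a higher number here means that the compound lasts longer, a lower number that the compound disappears faster), compound 2 reaches only the assay limit, < 0.16 h, which is a limit and not a number (the limit of < 0.16 h in this assay, at which 1 of the 2 values shown sits). Compound 1 stands at the other limit, >= 0.97 h, again a limit and not a number (the limit of >= 0.97 h in this assay, at which 1 of the 2 values shown sits). Compound 3 `COC(=O)CCNC(=O)[C@@H]1O[P@@](=O)(OCOC(=O)c2cc(C)nn2C)OCC1(C)C` is the next step: the two compounds have the same atoms and bonds and differ only in configuration as drawn: 1 of 2 stereo elements differ; a stereocentre at a phosphorus is drawn R in compound 2 and S in compound 3. Compound 3 shares the drawn phosphorus configuration of compound 1, and compound 1 sits at the upper limit in this assay. A step beyond the scatter, toward a longer half-life, is therefore expected from compound 2 to compound 3, an at least 5.0-fold higher number from compound 2 to compound 3 (0.69 log units; beyond the scatter). Compound 3 is estimated at 0.8 h, within 0.2 h to 3 h.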

Compound 3, half-life: > 1 h
Compound 3 ended at the assay's limit; the forecaster's own chance of this, stated with the estimate: 40%; middle value at least 1.2-fold (0.09 log units) away from the limit.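

In this assay the phosphorus configuration alone gives an at least 6.2-fold higher number from compound 2 to compound 3 (0.79 log units; beyond the scatter). Going by these compounds, compound 3 gives > 1 h, which is a limit of the assay and not a number, so the true size of this step stays unknown. The pair isolates the stereocentre at phosphorus, with no other change in the structure: the fact that compounds 2 and 3 differ only in the configuration as drawn

The step between compound 1 and compound 3 cannot be read, since both values are limits. On these data alone, whether the phosphorus configuration gives a similar gap with a carboxylic acid in place of the methyl ester remains open.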